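The compounds below may be only part of what the source reports. "The series", "measured", "known", "first", "only" and "open" are said of these compounds alone.

Compound 1, `COc1ccc(N2CCN(Cc3csc(N)c3C(=O)c3ccc(Cl)cc3)CC2)cc1`, gives 0% in an assay on CHO cells for displacement of a labelled ligand from adenosine receptor A3 (Homo sapiens), read by scintillation counting, with a stated time of 120 min, tested at 10 uM; on this read-out lower numbers stand for less inhibition and higher numbers for more inhibition at the one concentration tested (going by the name of the read-out).
Compound 2, `Nc1scc(CN2CCN(c3cccnc3)CC2)c1C(=O)c1ccc(Cl)cc1`, gives 0%.
Compound 3, `Nc1scc(CN2CCN(c3ccccc3F)CC2)c1C(=O)c1ccc(Cl)cc1`, gives 0%.

Compound 3 stands level with its two neighbours. Against compound 1 the step is no change at the digits printed from compound 1 to compound 3 (within the scatter), and against compound 2 it is no change at the digits printed from compound 2 to compound 3 (within the scatter); the step between the neighbours themselves is no change at the digits printed from compound 1 to compound 2 (within the scatter). None of the three measured compounds shows any inhibition at the single concentration tested, so the shared core with these varied aryl groups on the ring nitrogen has so far given no signal at all.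

Compound 4 is `Nc1scc(CN2CCN(c3cc(F)cc(F)c3)CC2)c1C(=O)c1ccc(Cl)cc1`. It differs from compound 3 as follows: 3,5-difluorophenyl in place of 2-fluorophenyl on an amine nitrogen in a ring.

Going by the values given here, the steps that bear on this change are the three exchanges of the aryl group on the same ring nitrogen, each of which left the read-out unchanged within the scatter. A fourth aryl group of the same kind, carrying two fluorines where one stood before, gives no reason to expect a departure from that picture. The expected step in this assay from compound 3 to compound 4 is therefore no change at the digits printed from compound 3 to compound 4 (within the scatter). Compound 4 is estimated to give 0%, in the range from -5% to 10%.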

Compound 4, a percentage reported as inhibition, at one concentration (the size of the read-out at that concentration, not a potency): 2%
The estimate for compound 4 lay 2 percentage points below the measured number; low and high end bracket the measured number.
By their numbers in this assay, from the lowest: compounds 1, 2, 3 and 4 (each within the scatter of the next).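

Placing 3,5-difluorophenyl on the amine nitrogen in the ring gives a number 2 percentage points higher from compound 3 to compound 4 (within the scatter) in this assay and, against the other two aryl groups, a number 2 percentage points higher from compound 2 to compound 4 (within the scatter) as well as a number 2 percentage points higher from compound 1 to compound 4 (within the scatter) in the same read-out. The earlier compounds shown here carried a single fluorine, a single methoxy group or a ring nitrogen on the aryl group, so this result extends the series to a phenyl ring with two fluorines, and across these four aryl groups no reading stands apart from the others. Nothing measured here offers an explanation for these readings.

The compounds shown leave open whether anything other than a directly attached aromatic ring on this nitrogen, such as a benzyl group, an acetyl group or a plain alkyl chain, would give a reading that stands clear of the scatter. They also leave open whether a change elsewhere on the shared core, such as an amide in place of the free amine or a different group in place of the chlorine, would do so at the single concentration tested.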